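The source may report more compounds than this note shows. Statements on the series, on what has been measured and on what is new or still open speak of the compounds shown alone.

In an assay on HEK293 cells for inhibition of solute carrier family 22 member 12 (Homo sapiens), read by scintillation counting, with a stated time of 12 min (on this read-out higher numbers stand for weaker inhibition and lower numbers for stronger inhibition), compound 1 `O=C(O)C1(Sc2ccnc3cccnc23)CCC1` gives only a limit, > 10000 nM. Compound 2 `COCc1ccc2nccc(SC3(C(=O)O)CCC3)c2c1`, which carries a methoxymethyl on the shared core, gives 198 nM in this assay. Going by the values given here, that is the only full number in the set so far; the other entry is the limit (the limit of > 10000 nM in this assay, at which 1 of the 2 values shown sits). Compound 3 `O=C(O)C1(Sc2ccnc3ccc(-c4ccc(F)cc4)cc23)CCC1` differs from compound 2 by 4-fluorophenyl in place of methoxymethyl on an aromatic carbon. Among the compounds with values here, no step between two measured compounds covers this exchange, so its size rests on expectation alone. Compound 3 is expected to come out stronger, with a step of a 2.5-fold lower number from compound 2 to compound 3 (0.39 log units; beyond the scatter) beyond the scatter. The estimate for compound 3 is 80 nM, within 20 nM to 400 nM.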

Compound 3, half-maximal inhibitory concentration: 159 nM
The estimate for compound 3 lay 2.0-fold (0.30 log units) below the measured number; measured number inside the range.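

In this assay, 4-fluorophenyl in place of methoxymethyl on this aromatic carbon gives a 1.2-fold lower number from compound 2 to compound 3 (0.10 log units; within the scatter). This position therefore accepts a six-membered aromatic ring of carbon only, with 7 heavy atoms against 3, without a step beyond the scatter. No measured property available here bears on this step.

From the compounds shown here alone, it remains open whether an amine or a nitrile on this aromatic carbon would stay level with compound 2 and compound 3. Going by these compounds, it is also open whether a plain phenyl would read the same as 4-fluorophenyl.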